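The compounds below may be only part of what the source reports. "The series", "measured", "known", "first", "only" and "open" are said of these compounds alone.

Compound 2, `COc1cc(-c2cc(/C=C/C(=O)c3ccc(N)cc3)[nH]n2)cc(OC)c1OC`, is one of two compounds tested in a functional assay on MDA-MB-435 cells (Homo sapiens) for inhibition, read by sulforhodamine B assay, with a stated time of 48 h (on this read-out lower numbers stand for stronger inhibition of growth and higher numbers for weaker inhibition of growth), where compound 2 gives 1660 nM. Its companion compound 1, `COc1ccc(-c2cc(/C=C/C(=O)c3ccc(N)cc3)[nH]n2)cc1`, gives 2240 nM in this assay, a value within the usual scatter of that of compound 2, so the two cannot be told apart on these numbers. Compound 3, `COc1ccc(-c2cc(/C=C/C(=O)c3ccc(N)cc3)[nH]n2)cc1OC`, differs from compound 2 by hydrogen in place of methoxy on an aromatic carbon. Going by the values given here, no measured pair shows such a step. The expected change is therefore a 1.1-fold higher number from compound 2 to compound 3 (0.06 log units; within the scatter), nothing beyond the scatter. Compound 3 is estimated to give about 1900 nM in this assay, most likely between 900 nM and 4000 nM.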

Compound 3, concentration for 50% growth inhibition: 2530 nM
Compound 3: the middle estimate sits 1.3-fold (0.12 log units) below what was measured, within the range that was stated.
By their numbers in this assay, from the lowest: compounds 2, 1 and 3 (each within the scatter of the next).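

Putting hydrogen in place of methoxy on this aromatic carbon, ortho to a methoxy group, gives a 1.5-fold higher number from compound 2 to compound 3 (0.18 log units; within the scatter) and so leaves growth inhibition unresolved from compound 2. Putting methoxy in place of hydrogen on an aromatic carbon of compound 1 gives a 1.1-fold higher number from compound 1 to compound 3 (0.05 log units; within the scatter) and likewise stays within the scatter. Among these three compounds, one methoxy more or fewer on this ring makes no readable difference, and nothing available bears on why.

On these data alone, whether a hydroxyl group, an amine or a fluorine atom at this carbon would shift the number remains open.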